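This account rests on a few compounds, and the source may have more. Where it says the series, first, only, none or still open, it means among the compounds named here.

Compound 1 `CCc1cccc(NC(=O)CN2CCN(c3ccccn3)CC2)c1` is the reference point of this small set. In a functional assay on cells for agonist activity at D(4) dopamine receptor (Homo sapiens), read by TR-FRET and cAMP accumulation, with a stated time of 30 min (on this read-out lower numbers stand for an effect already at smaller amounts and higher numbers for an effect only at larger amounts of compound), compound 1 gives 28.7 nM, the lowest of the two numbers that have been reported. Compound 3 `Cc1cccc(NC(=O)CCN2CCN(c3ncccn3)CC2)c1` differs from compound 1 in its core and in the length of the chain between the carbonyl and the ring nitrogen. In this assay compound 3 gives 568 nM, a number well above that of compound 1 and beyond the usual scatter. Compound 2 `CCc1cccc(NC(=O)CN2CCN(c3ccc(Cl)cn3)CC2)c1` is a close relative of compound 1. In this assay compound 2 is recorded as "not active" (no number reported) and no number is given for it.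

Compound 4 `O=C(CN1CCN(c2ccccn2)CC1)Nc1cncnc1` is the next compound to be measured. It departs from compound 1 by one change: pyrimidin-5-yl in place of 3-ethylphenyl on an amide-type nitrogen. Going by the values given here, no measured pair within the set shows this kind of exchange, so nothing in the existing numbers fixes its size or direction. The step from compound 1 to compound 4 is expected to be a 10-fold higher number from compound 1 to compound 4 (1.02 log units; beyond the scatter), a move toward a higher number and beyond the scatter. Compound 4 is therefore estimated to give 300 nM, with a likely range from 60 nM to 2000 nM.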

Compound 4, half-maximal effective concentration: "not active" (no number reported)
Compound 4: no number reported, and the estimate cannot be compared.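

Going by these compounds alone, compound 4 is recorded as "not active" in this assay with no number, so no step from compound 1 can be read. The compounds shown leave open how far pyrimidin-5-yl in place of 3-ethylphenyl moves the number, and no measurement here offers an explanation.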